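Hydroxy to Methoxy Across Two Compound Pairs

This account rests on a few compounds, and the source may have more. Where it says the series, first, only, none or still open, it means among the compounds named here.

Compound 1 `CC(C)(CNC(=O)c1ccc2ccccc2c1O)CC1=C(O)C(=O)c2ccccc2C1=O` and compound 2 `COc1c(C(=O)NCC(C)(C)CC2=C(O)C(=O)c3ccccc3C2=O)ccc2ccccc12` differ by methyl in place of hydrogen on an oxygen on an aromatic ring. In a functional assay on MCF7 cells (Homo sapiens) for cytotoxicity, read by resazurin assay, with a stated time of 3 days (on this read-out lower numbers stand for stronger inhibition and higher numbers for weaker inhibition), compound 1 gives 79500 nM, and compound 2 gives 39800 nM, which is a 2.0-fold lower number from compound 1 to compound 2 (0.30 log units; within the scatter). Compound 3 `COc1ccc(O)c(C(=O)NCC(C)(C)CC2=C(O)C(=O)c3ccccc3C2=O)c1` is built on another core; the difference between the two cores is not broken down here. In this assay compound 3 gives 39600 nM, a number close to that of compound 2. Compound 4 `COc1ccc(OC)c(C(=O)NCC(C)(C)CC2=C(O)C(=O)c3ccccc3C2=O)c1` differs from compound 3 by methyl in place of hydrogen on an oxygen on an aromatic ring, the same change as in the first pair, at a place described in the same words. The step from compound 3 to compound 4 is expected to be a 1.6-fold lower number from compound 3 to compound 4 (0.20 log units; within the scatter), because the matched pair showed a 2.0-fold lower number from compound 1 to compound 2 (0.30 log units; within the scatter). Compound 4 is therefore estimated at 25000 nM in this assay, most likely between 10000 nM and 70000 nM.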

Compound 4, half-maximal inhibitory concentration: 99400 nM
Beside the measured number, compound 4's estimate is 4.0-fold (0.60 log units) below it; measured number outside the range, above it.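

Hydroxy to methoxy on the 2-hydroxy-5-methoxyphenyl group gives a 2.5-fold higher number from compound 3 to compound 4 (0.40 log units; beyond the scatter) in this assay. Set beside the earlier pair, the same change does not carry unaltered from one core to the other: the same change on two cores in this assay, a 2.0-fold lower number (0.30 log units; within the scatter) from compound 1 to compound 2 and a 2.5-fold higher number (0.40 log units; beyond the scatter) from compound 3 to compound 4, 5.0-fold (0.70 log units) apart, beyond the scatter of two such steps. In these two pairs, the result on one core was therefore no guide to the result on the other, but the data do not show why the two cores differ, and two pairs give no rule for any further core. The compounds shown leave open whether a longer chain on that oxygen, such as ethoxy, or an amine in place of the hydroxy would follow the step on either core.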